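Methoxy on the phenyl ring of compound 3

The source may report more compounds than this note shows. Statements on the series, on what has been measured and on what is new or still open speak of the compounds shown alone.

In a functional assay on K562 cells (Homo sapiens) for antiproliferative activity, read by MTT assay, with a stated time of 72 h (a lower number here means a stronger inhibitor, a higher number a weaker inhibitor), compound 1 (`COc1cc(-n2ncnc2-c2ccc(C)cc2)cc(OC)c1OC`) gives > 10000 nM as a limit, not a number. Compound 2 (`COc1cc(-n2ncnc2-c2ccc(OC(F)(F)F)cc2)cc(OC)c1OC`) gives > 10000 nM as a limit as well. Compound 3 (`COc1cc(-n2ncnc2-c2ccccc2)cc(OC)c1OC`) gives > 10000 nM as a limit too, so its place is only the limit of > 10000 nM in this assay, at which 3 of the 3 values shown sit, and no more. Compound 4 (`COc1ccccc1-c1ncnn1-c1cc(OC)c(OC)c(OC)c1`) has methoxy in place of hydrogen on an aromatic carbon, ortho to a large group (methoxy in place of hydrogen on an aromatic carbon). Among the measured compounds shown here, the nearest measured changes give no size: a step that the two limits leave unreadable from compound 1 to compound 3 and a step that the two limits leave unreadable from compound 2 to compound 3 stand with a step that the two limits leave unreadable from compound 1 to compound 2 as the only guides. No shift beyond the scatter is therefore expected in this assay. The expected change is a step that the limit leaves unreadable from compound 3 to compound 4 by estimate. Compound 4 is estimated at 12000 nM with an expected range from 4000 nM to 40000 nM and a limit as the likeliest report.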

Compound 4, half-maximal inhibitory concentration: > 10000 nM
Compound 4: no number, only a limit; the forecaster's own chance of this, stated with the estimate: 85%; the middle value does not contradict the limit.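

No step can be read for compound 4 against compound 3 or compound 1, since each pair gives only limits: the limit of > 10000 nM in this assay, at which 4 of the 4 values shown sit.

The compounds shown leave open which phenyl substituent, if any, would give a readable number.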